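A few compounds are considered here, and "the series" means these few. Any claim that something is new, unique, unknown or untested is made for them only; others in the source may bear on it.

Measured compounds:
Compound 1, `Cc1cccc(C(=O)/C=C/c2ccc3c(c2)B(O)OC3)c1` — 8.56 ug/mL
Compound 2, `COc1cccc(C(=O)/C=C/c2ccc3c(c2)B(O)OC3)c1` — > 10 ug/mL

Going by the values given here, in an ADME assay on L929 cells (Mus musculus) for cytotoxicity, read by resazurin assay, with a stated time of 72 h (a higher number here means a weaker inhibitor, a lower number a stronger inhibitor), compound 1 gives 8.56 ug/mL, the only number the series has so far. Compound 2 is reported in this assay only as a limit, > 10 ug/mL. The step of an at least 1.1-fold higher number from compound 1 to compound 2 (0.06 log units; that floor lies within the scatter) therefore cannot be sized precisely, since compound 2 sits at the limit of > 10 ug/mL in this assay, at which 1 of the 2 values shown sits.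

Compound 3, `Cc1ccc(C(=O)/C=C/c2ccc3c(c2)B(O)OC3)cc1`, remains to be measured in this assay. It differs from compound 1 as 4-methylphenyl in place of 3-methylphenyl on a carbonyl carbon. Among the compounds with values here, the one measured step swaps the group itself rather than moving a methyl, so nothing measured bears directly on this change. Compound 3 is therefore expected to stay close to compound 1, near 9 ug/mL, between 4.5 ug/mL and 18 ug/mL. For compound 3 this expectation means a step of a 1.1-fold higher number from compound 1 to compound 3 (0.02 log units; within the scatter), within the usual scatter.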

Compound 3, half-maximal inhibitory concentration: > 10 ug/mL
Compound 3: no number, only a limit (the forecaster's own chance of this, stated with the estimate: 35%); middle value at least 1.1-fold (0.04 log units) away from the limit.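

Moving the methyl, with 4-methylphenyl in place of 3-methylphenyl on a carbonyl carbon, is the first change here that keeps the same atoms and joins them differently, and in this assay it gives an at least 1.1-fold higher number from compound 1 to compound 3 (0.06 log units; that floor lies within the scatter). Compound 3 has no number in this assay, only a limit, so the change of methyl place can be read only as a floor, and that floor does not show that the place of the methyl matters. What the series adds is that the limit is now the more common reading, with compound 2 and compound 3 both reported this way: the limit of > 10 ug/mL in this assay, at which 2 of the 3 values shown sit.

As far as these compounds go, how far compound 2 and compound 3 actually lie from compound 1 stays open. Also open, from the compounds shown here alone, is whether an amine or a carboxylic acid in place of the methyl would give a number rather than a limit.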